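The source may hold more compounds than are shown below. What is called first, only, known or untested is meant among the compounds shown, and "the series" means these compounds.

Compound 1 `CC(=O)OC[C@H]1O[C@H](OC[C@@H](Cn2cc(CN(c3nc(-c4cccc([N+](=O)[O-])c4)no3)C3CCCCC3)nn2)OC(C)=O)C=C[C@@H]1OC(C)=O`: > 200 ug/mL
Compound 2 `C#Cc1ccc(-c2noc(NC3CCCCC3)n2)cc1`: 54.2 ug/mL

Of the compounds shown here, two have been measured in an ADME assay on HepG2 cells (Homo sapiens) for cytotoxicity, read by MTT assay, with a stated time of 48 h; on this read-out lower numbers stand for higher toxicity in this test and higher numbers for lower toxicity in this test. Compound 1 `CC(=O)OC[C@H]1O[C@H](OC[C@@H](Cn2cc(CN(c3nc(-c4cccc([N+](=O)[O-])c4)no3)C3CCCCC3)nn2)OC(C)=O)C=C[C@@H]1OC(C)=O` gives only a limit in this assay, > 200 ug/mL. That is the limit of > 200 ug/mL in this assay, at which 1 of the 2 values shown sits. Compound 2 `C#Cc1ccc(-c2noc(NC3CCCCC3)n2)cc1` gives 54.2 ug/mL in this assay, and this is the only number shown. Compound 1 gives only a limit, so compound 2 cannot be placed above or below any measured neighbour.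

Compound 3 `C#CCN(c1nc(-c2ccc(C#C)cc2)no1)C1CCCCC1` has not yet been measured in this assay. It differs from compound 2 by propargyl in place of hydrogen on a nitrogen on an aromatic ring. No step between two measured compounds is shown, so the size of this kind of change cannot be read from a measured pair. The account therefore expects the step from compound 2 to compound 3 in this assay to be small, a 1.1-fold lower number from compound 2 to compound 3 (0.04 log units; within the scatter), not beyond the usual scatter in either direction. On that basis compound 3 is estimated at 50 ug/mL in this assay, with a range from 20 ug/mL to 140 ug/mL, and the measurement that follows will show whether this holds.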

Compound 3, half-maximal cytotoxic concentration: 28 ug/mL
Compound 3: middle estimate off by 1.8-fold (0.25 log units), on the high side; the range from low to high includes it.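

In this assay, for the compounds shown here, the first step that can be read at this place, a nitrogen on an aromatic ring whose other neighbours are aromatic carbon and saturated ring carbon, is propargyl in place of hydrogen: a 1.9-fold lower number from compound 2 to compound 3 (0.29 log units; within the scatter). The change adds 3 heavy atoms, a triple bond outside aromatic rings and no hydrogen-bond donors or acceptors, and on this single pair it does not move the read-out beyond the usual scatter, with compound 2 and compound 3 both giving a number and not a limit. Nothing measured here gives a cause for this step.

As far as these compounds go, whether an amine, a carboxylic acid or a longer chain on this nitrogen would take the number beyond the scatter stays open, as this one step says nothing about groups other than propargyl. Going by these compounds alone, compound 1 gives only a limit, it differs from the other compounds in more than one place, and no step to it can be read.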